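This account rests on a few compounds, and the source may have more. Where it says the series, first, only, none or still open, it means among the compounds named here.

Measured compounds:
- Compound 1 `COC(CC(OC)OC)Cn1nnnc1C(Nc1ccc([Se][Se]c2ccc(NC(c3nnnn3CC(CC(OC)OC)OC)C(C)C)cc2)cc1)C(C)C`: in a functional assay on HepG2 cells (Homo sapiens) for cytotoxicity, read by MTT assay, with a stated time of 48 h (a higher number here means a weaker inhibitor, a lower number a stronger inhibitor), compound 1 gives 47000 nM
- Compound 2 `CC1=C([Se]c2ccc(NCc3nnnn3C(C)(C)C)cc2)C(=O)c2ccccc2C1=O`: in this assay compound 2 gives 33000 nM

Compound 2 has the lower of the two numbers, but its value and that of compound 1 lie within the usual scatter of each other, so the two cannot be ranked. Compound 3 `CC1=C([Se]c2ccc(NC(c3ccco3)c3nnnn3C(C)(C)C)cc2)C(=O)c2ccccc2C1=O` is built from compound 2 by furan-2-yl in place of hydrogen on a saturated chain carbon bound to an aromatic carbon and a nitrogen on an aromatic ring. For the measured compounds named here, no measured pair shows what such a change does in this assay, so there is no step to lean on. The single-point change is expected to shift the number little, most likely by no more than the scatter and in no sure direction. Compound 3 is therefore expected to give about 25000 nM in this assay, within a range of 8000 nM to 80000 nM. This estimate implies a step of a 1.3-fold lower number from compound 2 to compound 3 (0.12 log units; within the scatter), which is expected to stay within the scatter.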

Compound 3, half-maximal inhibitory concentration: 9000 nM
Estimate against measurement, compound 3: 2.8-fold (0.44 log units) above; low and high end bracket the measured number.
By their numbers in this assay, from the lowest: compound 3; then compounds 2 and 1 (each within the scatter of the next).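

In this assay, furan-2-yl in place of hydrogen on a saturated chain carbon bound to an aromatic carbon and a nitrogen on an aromatic ring gives a 3.7-fold lower number from compound 2 to compound 3 (0.56 log units; beyond the scatter), a step beyond the scatter. For the compounds shown here, this is the first sign that the number responds to a change at this position, as compound 1 and compound 2 could not be ranked and differ in more than one place. Nothing shown explains why the number moved with this change.

Going by these compounds, whether the step belongs to furan-2-yl in particular or would follow from other groups on this carbon remains open, for instance a methyl group, a phenyl ring or a thiophene ring. Also open, on these data alone, is whether the same change would move the number on the core of compound 1.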